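The source may hold more compounds than are shown below. What is called first, only, known or untested is meant among the compounds shown, and "the series" means these compounds.

In a functional assay on MCF7 cells (Homo sapiens) for antiproliferative activity, read by sulforhodamine B assay, with a stated time of 48 h (on this read-out lower numbers stand for stronger inhibition and higher numbers for weaker inhibition), compound 1 `COc1cc(C=C(C(=O)/C=C/c2cccc(OC)c2OC)C(=O)/C=C/c2cccc(OC)c2OC)ccc1O` gives 480 nM and compound 2 `COc1cccc(/C=C/C(=O)C(=Cc2ccc(OC)c(OC)c2OC)C(=O)/C=C/c2cccc(OC)c2OC)c1OC` gives 380 nM while compound 3 `COc1ccc(OC)c(/C=C/C(=O)C(=Cc2ccc(O)c(OC)c2)C(=O)/C=C/c2cc(OC)ccc2OC)c1` gives 400 nM so compound 3 stands within the scatter of both, and no order can be read among the three. Compound 4 `COc1ccc(OC)c(/C=C/C(=O)C(=Cc2cc(OC)c(O)c(OC)c2)C(=O)/C=C/c2cc(OC)ccc2OC)c1` differs from compound 3 in one place methoxy in place of hydrogen on an aromatic carbon where methoxy replaces hydrogen on an aromatic carbon, turning 4-hydroxy-3-methoxyphenyl into 4-hydroxy-3,5-dimethoxyphenyl. Among the measured compounds shown here, the one measured step that bears on this also changes 4-hydroxy-3-methoxyphenyl, here to 2,3,4-trimethoxyphenyl, and gives a 1.3-fold lower number from compound 1 to compound 2 (0.10 log units; within the scatter) as its size. An estimated 1.1-fold lower number from compound 3 to compound 4 (0.06 log units; within the scatter) in this assay is therefore expected, which is no step beyond the scatter. Compound 4 is thus estimated at 350 nM (expected range 170 nM to 750 nM).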

Compound 4, half-maximal inhibitory concentration: 430 nM
Beside the measured number, compound 4's estimate is 1.2-fold (0.09 log units) below it; the range from low to high includes it.
By their numbers in this assay, from the lowest: compounds 2, 3, 4 and 1 (each within the scatter of the next).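

In this assay, putting methoxy in place of hydrogen on an aromatic carbon, ortho to a hydroxy group, gives a 1.1-fold higher number from compound 3 to compound 4 (0.03 log units; within the scatter) and so no readable change. The earlier step replaced a whole substituted ring at once, whereas this one alters a single group and shows that this position accepts a methoxy without a readable shift. No measurement here offers an explanation for this result.

From the compounds shown here alone, whether an amine, a carboxylic acid or a longer alkoxy chain at this position would move the number beyond the scatter remains open.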